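Replacing an Amide-type Hydrogen with 3-Methylphenyl

The compounds below may be only part of what the source reports. "The series", "measured", "known", "first", "only" and "open" are said of these compounds alone.

Compound 1 `NC(=S)N/N=C/c1ccc2ccccc2n1` carries a free amino group on the thiocarbonyl carbon of the shared core. Within the data shown here, in a functional assay on HeLa cells (Homo sapiens) for antiproliferative activity, read by sulforhodamine B assay, with a stated time of 72 h (a lower number here means a stronger inhibitor, a higher number a weaker inhibitor), compound 1 gives 960 nM, the second highest of the three numbers measured so far. Among the measured compounds shown here, compound 3 `CN(C)C(=S)N/N=C/c1ccc2ccccc2n1` gives 90 nM, and the one recorded step, an 11-fold lower number from compound 1 to compound 3 (1.03 log units; beyond the scatter), is large. Compound 2 `CC(C)c1cccc(C(C)C)c1NC(=S)N/N=C/c1ccc2ccccc2n1`, with a much larger group on the same nitrogen, gives 16400 nM, a far higher number than compound 1. Compound 4 `Cc1cccc(NC(=S)N/N=C/c2ccc3ccccc3n2)c1` differs from compound 1 by 3-methylphenyl in place of hydrogen on an amide-type nitrogen. For the measured compounds named here, no measured step covers this exact change; the values of compound 1 and compound 2 show that a group on this nitrogen can raise the number sharply, though 3-methylphenyl need not go as far. A modest upward step is therefore expected, a 2.1-fold higher number from compound 1 to compound 4 (0.32 log units; beyond the scatter). For compound 4 the estimate is 2000 nM, within 400 nM to 10000 nM.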

Compound 4, half-maximal inhibitory concentration: > 100000 nM
Compound 4: only a limit was reported; the forecaster's own chance of this, stated with the estimate: 5%; at least 50-fold (1.69 log units) between middle value and limit.
By their numbers in this assay, from the lowest: compound 3; then compound 1; then compound 2. At a limit, above all of these: compound 4.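

In this assay, among these compounds, 3-methylphenyl on this amide-type nitrogen gives an at least 100-fold higher number from compound 1 to compound 4 (2.01 log units; beyond the scatter), a far larger penalty than the earlier compounds indicated. Compound 2, with a larger group on the same nitrogen, still gives 16400 nM, so among these compounds the number does not simply rise with group size. For compound 4 the reading is only a limit, not a number: the limit of > 100000 nM in this assay, at which 1 of the 4 values shown sits.

The compounds shown leave open whether a butyl chain on this nitrogen would keep the number low. They also leave open how a phenyl ring carrying an amine or a carboxylic acid would behave there.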